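Swapping a fluorophenyl for a furan on the shared core

A few compounds are considered here, and "the series" means these few. Any claim that something is new, unique, unknown or untested is made for them only; others in the source may bear on it.

Measured so far:
- compound 1, `O=C(Nn1c(-c2cccc([N+](=O)[O-])c2)nc2c(-c3ccco3)n[nH]c2c1=O)c1cccnc1`: 1.51%
- compound 2, `O=C(Nn1c(-c2cccc([N+](=O)[O-])c2)nc2c(-c3cccc(Cl)c3)n[nH]c2c1=O)c1ccccc1`: "not determined" (no result reported)
- compound 3, `O=C(Nn1c(-c2cccc([N+](=O)[O-])c2)nc2c(-c3ccc(F)cc3)n[nH]c2c1=O)c1ccccc1`: 80.7%

In a functional assay on A549 cells (Homo sapiens) for cytotoxicity, read by sulforhodamine B assay, with a stated time of 2 days, tested at 100 uM (on this read-out lower numbers stand for less inhibition and higher numbers for more inhibition at the one concentration tested (going by the name of the read-out)), compound 3 gives 80.7%, the highest of the two numbers available. Its nearest neighbour is compound 1, which in this assay gives 1.51%, a value far lower than that of compound 3 and beyond the usual scatter. In this assay compound 2 gives "not determined" (no result reported), so it adds nothing to the comparison.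

The unmeasured compound 4 is `O=C(Nn1c(-c2cccc([N+](=O)[O-])c2)nc2c(-c3ccco3)n[nH]c2c1=O)c1ccccc1`. It differs from compound 3 in one place: furan-2-yl in place of 4-fluorophenyl on an aromatic carbon. Among the compounds with values here, no step between two measured compounds that differ in exactly this way is available, so the direction must be read from what the two numbers show. Compound 4 bears the same furan-2-yl group as compound 1. In this assay compound 1 gives 1.51%, while compound 3 with its 4-fluorophenyl gives 80.7%. On that basis a sizeable downward step is expected in this assay, beyond the scatter, though with a wide margin since compound 1 and compound 4 also differ elsewhere. For compound 4 the expected step is a number 50.7 percentage points lower from compound 3 to compound 4 (beyond the scatter) in this assay. Compound 4 is estimated at 30%, within a range from 2% to 80%.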

Compound 4, a percentage reported as inhibition, at one concentration (the size of the read-out at that concentration, not a potency): 18.7%
Compound 4: middle estimate off by 11.3 percentage points, on the high side; the measured number falls inside the stated range.
By their numbers in this assay, from the lowest: compound 1; then compound 4; then compound 3.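

In this assay, furan-2-yl in place of 4-fluorophenyl on the aromatic carbon gives a number 62 percentage points lower from compound 3 to compound 4 (beyond the scatter), so a change at this position alone, with everything else held fixed, accounts for a large step. The earlier compounds shown here could not show this, since compound 1 and compound 3 differ in two places. The other change, phenyl in place of pyridin-3-yl on a carbonyl carbon, gives a number 17.2 percentage points higher from compound 1 to compound 4 (beyond the scatter), a modest step with furan-2-yl held in place, which shows that the carbonyl end also moves the read-out, though less than the swap on the aromatic carbon; no accompanying measurement bears on why either number moves.

Going by these compounds, what remains open is whether the large step follows from the loss of the 4-fluorophenyl group in particular or would also appear with a quite different group at this position, such as a morpholine ring or a simple methyl. On these data alone, it is also open whether the step from pyridin-3-yl to phenyl would keep its direction and size with 4-fluorophenyl on the aromatic carbon instead of furan-2-yl.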